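The source may hold more compounds than are shown below. What is called first, only, known or untested is meant among the compounds shown, and "the series" means these compounds.

In a functional assay on A549 cells (Homo sapiens) for cytotoxicity (on this read-out higher numbers stand for an effect only at larger amounts of compound and lower numbers for an effect already at smaller amounts), compound 1 (`c1ccc(COc2cc(-c3ccccc3)nc3ccccc23)cc1`) gives > 10 ug/mL, which is a limit of the assay and not a number. Compound 1 thus stands at the limit of > 10 ug/mL in this assay, at which 1 of the 2 values shown sits, with no exact value. Also in this assay compound 2 (`Oc1ccc2c(O)cc(-c3ccccc3)nc2c1`) gives 0.81 ug/mL as a measured number. Compound 3 (`CCCCOc1cc(-c2ccccc2)nc2ccccc12`) differs from compound 1 in one group, (propyl in place of phenyl on a saturated chain carbon bound to an oxygen on an aromatic ring), with propyl in place of phenyl on a saturated chain carbon bound to an oxygen on an aromatic ring, which reads as benzyloxy to butoxy. Among the measured compounds shown here, no measured pair covers this change, so the expectation rests only on the limit of compound 1, > 10 ug/mL, and in this assay no step beyond the scatter is expected. The estimate for this change is a step that the limit leaves unreadable from compound 1 to compound 3, with no clear direction expected. For compound 3 the expected value is 12 ug/mL, within an estimated range from 4 ug/mL to 40 ug/mL, and a further limit would be no surprise.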

Compound 3, half-maximal effective concentration: > 10 ug/mL
Compound 3: no number, only a limit; the forecaster's own chance of this, stated with the estimate: 60%; the middle value does not contradict the limit.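

Compound 1 and compound 3 both give only a limit and not a number, so no step can be read between them: the limit of > 10 ug/mL in this assay, at which 2 of the 3 values shown sit.

The compounds shown leave open how large the change from benzyloxy to butoxy really is, and in which direction it goes.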